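The source may hold more compounds than are shown below. What is called first, only, known or untested is meant among the compounds shown, and "the series" means these compounds.

Compound 1 `COc1ccccc1/C=C/S(=O)(=O)Cc1ccc(OC)c([N+](=O)[O-])c1` is the weaker of the two measured compounds in a functional assay on K562 cells (Homo sapiens) for cytotoxicity, read by trypan blue exclusion, with a stated time of 96 h (on this read-out lower numbers stand for stronger inhibition and higher numbers for weaker inhibition), where compound 1 gives 20000 nM. Among the compounds with values here, its only measured neighbour is compound 2 `COc1ccc(CS(=O)(=O)/C=C/c2ccccc2OC)cc1N`, which in this assay gives 7500 nM; the step of a 2.7-fold lower number from compound 1 to compound 2 (0.43 log units; beyond the scatter) is the single measured change in the set. Compound 3 `COc1ccc(/C=C/S(=O)(=O)Cc2ccc(OC)c([N+](=O)[O-])c2)cc1` has not yet been tested. It differs from compound 1 by 4-methoxyphenyl in place of 2-methoxyphenyl on a double-bonded chain carbon bound to a double-bonded chain carbon. Within the data shown here, no measured step touches this part of the molecule: the one step that is known concerns the amino in place of nitro on an aromatic carbon, and so says nothing about moving the methoxy group on the ring at the double-bonded chain carbon. Among the measured compounds shown here, with no relevant step to guide it, the expectation is that this assay shows no change beyond the scatter, so the step from compound 1 to compound 3 is estimated as no change at the digits printed from compound 1 to compound 3 (within the scatter). Compound 3 is therefore expected to give about 20000 nM, within a range from 7000 nM to 55000 nM.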

Compound 3, half-maximal inhibitory concentration: 25000 nM
Beside the measured number, compound 3's estimate is 1.3-fold (0.10 log units) below it; measured number inside the range.
By their numbers in this assay, from the lowest: compound 2; then compounds 1 and 3 (each within the scatter of the next).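

In this assay, 4-methoxyphenyl in place of 2-methoxyphenyl on a double-bonded chain carbon bound to a double-bonded chain carbon gives a 1.3-fold higher number from compound 1 to compound 3 (0.10 log units; within the scatter) and so the exchange leaves the reading within the scatter on this nitro-bearing core. Within the data shown here, this is the first reading at this position, since the earlier step of a 2.7-fold lower number from compound 1 to compound 2 (0.43 log units; beyond the scatter) concerned only amino in place of nitro on an aromatic carbon, and that step remains the only one beyond the scatter. No measured evidence here bears on why compound 1 and compound 3 read alike.

The compounds shown leave open whether 4-methoxyphenyl would read the same on the amino-bearing core of compound 2. They also leave open whether a hydroxyl group, a carboxylic acid or a longer alkoxy chain in place of the methoxy group would shift the number in this assay at all.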